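A few compounds are considered here, and "the series" means these few. Any claim that something is new, unique, unknown or untested is made for them only; others in the source may bear on it.

Solubility across the series is read by a physicochemical assay for solubility, with a stated time of 18 h, at pH 7.4; on this read-out higher numbers stand for higher solubility and lower numbers for lower solubility. Compound 1 `COc1cccc(CNCCCNc2ccnc3cc(-c4ccc(F)cc4)ccc23)c1O` gives 32000 nM. Compound 2 `COc1ccc(Oc2ccc3c(NCCCNCc4cccc(OC)c4O)ccnc3c2)cc1` gives 14500 nM, and compound 3 `COc1cccc(CNCCCNc2ccnc3cc(Oc4cccc(N(C)C)c4)ccc23)c1O` gives 14500 nM. The two measured steps away from compound 1 run the same way: a 2.2-fold lower number from compound 1 to compound 2 (0.34 log units; beyond the scatter) and a 2.2-fold lower number from compound 1 to compound 3 (0.34 log units; beyond the scatter), each a modest fall when 4-methoxyphenoxy or 3-(dimethylamino)phenoxy replaces 4-fluorophenyl. Between the two phenoxy-bearing compounds there is no change at the digits printed from compound 2 to compound 3 (within the scatter). Compound 3 thus sits level with compound 2 at the bottom of the three values, with compound 1 the furthest from it.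

Compound 4 `COc1cccc(CNCCCNc2ccnc3cc(Cc4ccccc4)ccc23)c1O` differs from compound 3 in one place: benzyl in place of 3-(dimethylamino)phenoxy on an aromatic carbon. Going by the values given here, no measured step involves benzyl itself. The closest guide is compound 1, whose steps a 2.2-fold lower number from compound 1 to compound 2 (0.34 log units; beyond the scatter) and a 2.2-fold lower number from compound 1 to compound 3 (0.34 log units; beyond the scatter) show 4-fluorophenyl standing higher than either phenoxy group. Since compound 4 likewise drops the phenoxy group for a carbon-linked ring, the step is expected to run modestly upward, a 1.7-fold higher number from compound 3 to compound 4 (0.24 log units; within the scatter). For compound 4 the estimated solubility is 25000 nM, with a range from 10000 nM to 60000 nM.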

Compound 4, solubility: 4200 nM
Estimate against measurement, compound 4: 6.0-fold (0.77 log units) above; the whole stated range lies above it.
By their numbers in this assay, from the lowest: compound 4; then compounds 2 and 3 (each within the scatter of the next); then compound 1.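

At this aromatic carbon, benzyl gives the lowest solubility of the four groups in this assay, with a fall against each earlier compound (a 3.5-fold lower number from compound 3 to compound 4 (0.54 log units; beyond the scatter); a 3.5-fold lower number from compound 2 to compound 4 (0.54 log units; beyond the scatter); a 7.6-fold lower number from compound 1 to compound 4 (0.88 log units; beyond the scatter)). The earlier compounds shown here set 4-fluorophenyl above the two phenoxy groups, but compound 4 shows that a carbon link alone does not keep the number high, since the two carbon-linked groups now stand at opposite ends of the order. No measurement at hand accounts for the fall.

Still open, going by these compounds, is whether the low number goes with the methylene link or with the unsubstituted ring, which 4-fluorobenzyl or 3-(dimethylamino)benzyl would help separate. Also open, on these data alone, is how a longer chain such as phenethyl, or a carboxylic acid at this carbon, would read in this assay.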